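The compounds below may be only part of what the source reports. "The series", "measured", "known", "first", "only" and "open" are said of these compounds alone.

The protein in question is studied through an assay on isolated protein for inhibition of ubiquitin carboxyl-terminal hydrolase 7 (Homo sapiens), with stated times of 30 min and 2 h; on this read-out lower numbers stand for stronger inhibition and higher numbers for weaker inhibition. Of the compounds shown here, two have been measured in it. Compound 1, with the structure `Cn1nc2c(=O)n(CC3(O)CCN(Cc4ccc(-c5ccco5)cc4Cl)CC3)cnc2c1-c1ccc(CNS(C)(=O)=O)cc1`, gives 65.3 nM in this assay. Compound 2, with the structure `Cc1ccc(-c2ccc(CN3CCC(O)(Cn4cnc5c(-c6ccc(CN)cc6)n(C)nc5c4=O)CC3)c(Cl)c2)s1`, gives 101 nM in this assay. These two numbers lie within the usual scatter of each other, so the readings do not separate compound 1 from compound 2; compound 1 simply stands alongside compound 2 on the evidence so far.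

The next compound, compound 3, has the structure `Cn1nc2c(=O)n(CC3(O)CCN(Cc4ccc(-c5ccco5)cc4Cl)CC3)cnc2c1-c1ccc(CN)cc1`. It is derived from compound 1 by a single change: hydrogen in place of methylsulfonyl on an amine nitrogen. For the measured compounds named here, no pair of measured compounds shows this exact change in isolation, so its effect on this assay is not known from direct comparison. Compound 2 also carries an aminomethyl group rather than a (methanesulfonamido)methyl group, but it differs from compound 1 in a second place as well, so all that can be noted alongside this change is that compound 2 gives 101 nM.

For compound 3 the expected step of a 1.3-fold higher number from compound 1 to compound 3 (0.11 log units; within the scatter) is small, with no clear direction beyond the scatter. Compound 3 is estimated to give 85 nM in this assay, within a range from 30 nM to 250 nM.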

Compound 3, half-maximal inhibitory concentration: 18.1 nM
Estimate against measurement, compound 3: 4.7-fold (0.67 log units) above; the whole stated range lies above it.
By their numbers in this assay, from the lowest: compound 3; then compounds 1 and 2 (each within the scatter of the next).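

In this assay, for the compounds shown here, replacing the methylsulfonyl on the amine nitrogen with hydrogen, which turns (methanesulfonamido)methyl into aminomethyl, gives a 3.6-fold lower number from compound 1 to compound 3 (0.56 log units; beyond the scatter), so this position clearly affects the read-out, something no earlier pair could show. The new compound also isolates a change elsewhere in the molecule: with aminomethyl kept in place, furan-2-yl in place of 5-methylthiophen-2-yl on an aromatic carbon gives a 5.6-fold lower number from compound 2 to compound 3 (0.75 log units; beyond the scatter). Compound 1 and compound 2 could not be separated from each other, yet each differs from compound 3 in one place, and both of these single changes lead to a lower number, meaning stronger inhibition.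

Nothing available here explains why either change moves the number in this direction. The compounds shown leave open how an acetyl group or a single methyl on that nitrogen would compare with hydrogen and methylsulfonyl, and whether a phenyl ring in place of furan-2-yl would keep the lower number.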